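The source may report more compounds than this note shows. Statements on the series, on what has been measured and on what is new or still open speak of the compounds shown alone.

Compound 1 `COc1ccc(N2CCN(Cc3csc(N)c3C(=O)c3ccc(Cl)cc3)CC2)cc1`: -15%
Compound 2 `Nc1scc(CN2CCN(c3c(F)cccc3F)CC2)c1C(=O)c1cccc(C(F)(F)F)c1`: 1.3%
Compound 3 `Nc1scc(CN2CCN(c3cccc4ccccc34)CC2)c1C(=O)c1ccc(Cl)cc1`: 2.9%

All three were tested in a functional assay on CHO cells with adenosine receptor A1 (Homo sapiens) as the target, read by cAMP accumulation and immunoassay, with a stated time of 6 min, tested at 1 uM; on this read-out lower numbers stand for a stronger effect and higher numbers for a weaker effect at the one concentration tested. Among them compound 3 stands highest: its nearest neighbour is compound 2, whose number is lower by a margin within the scatter, and its furthest is compound 1, lower by a margin beyond the scatter. Within the data shown here, the only single-place step that has been measured, a number 17.9 percentage points higher from compound 1 to compound 3 (beyond the scatter), is a modest rise and concerns the group on the amine nitrogen in the ring, the same place that changes in the new compound.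

Compound 4 `Nc1scc(CN2CCN(c3ccc(Cl)c(Cl)c3)CC2)c1C(=O)c1ccc(Cl)cc1` differs from compound 3 in one place: 3,4-dichlorophenyl in place of naphthalen-1-yl on an amine nitrogen in a ring. Since the measured step at this place was modest, and compound 2, which carries yet another aryl group there, sits within the scatter of compound 3, no large movement is expected. For compound 4 the estimated step is a number 2.9 percentage points lower from compound 3 to compound 4 (within the scatter), which is not expected to leave the scatter. Compound 4 is therefore expected to give about 0%, within the range -14% to 14%.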

Compound 4, a percentage reported as activity, at one concentration (the size of the read-out at that concentration, not a potency): -60%
The estimate for compound 4 lay 60 percentage points above the measured number; the measured number lies below the stated range.
By their numbers in this assay, from the lowest: compound 4; then compound 1; then compounds 2 and 3 (each within the scatter of the next).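

Among these compounds, the group on the amine nitrogen in the ring proves far more sensitive than the earlier compounds suggested: in this assay, the change gives a number 62.9 percentage points lower from compound 3 to compound 4 (beyond the scatter) and a number 45 percentage points lower from compound 1 to compound 4 (beyond the scatter), both large. The 3,4-dichlorophenyl group, with one aromatic ring, thus separates itself from both 4-methoxyphenyl and the two-ring naphthalen-1-yl, so that with the rest of the molecule held constant, this one group alone can shift the read-out strongly towards the stronger effect. Nothing available explains why this group behaves so differently.

The compounds shown leave open whether both chlorines are needed, since a plain phenyl or a phenyl carrying one chlorine does not appear among them. They also leave open whether a pyridine ring at this place would keep the effect.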